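The source may report more compounds than this note shows. Statements on the series, on what has been measured and on what is new or still open speak of the compounds shown alone.

Compound 1 `COc1ccc2[nH]c(C(=O)N3CC(=O)N(Cc4ccccc4)[C@@H](COCc4ccccc4)C3)cc2c1`: in an ADME assay on Vero cells (Chlorocebus sabaeus) for cytotoxicity, with a stated time of 7 days (on this read-out higher numbers stand for lower toxicity in this test and lower numbers for higher toxicity in this test), compound 1 gives > 30000 nM, which is a limit of the measurement, not a number.
Compound 2 `COc1ccc2[nH]c(C(=O)N3CC(=O)N(Cc4ccccc4)[C@@H](N4[C@H](C)CCC[C@@H]4C)C3)cc2c1`: in this assay compound 2 gives 1400 nM.
Compound 3 `COc1ccc2[nH]c(C(=O)N3CC(=O)N(Cc4ccccc4)[C@@H](N4CCc5ccccc54)C3)cc2c1`: in this assay compound 3 gives > 100000 nM, again a limit.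

Compound 1 therefore stands at a limit (the limit of > 30000 nM in this assay, at which 1 of the 3 values shown sits), and the one other limit is the limit of > 100000 nM in this assay, at which 1 of the 3 values shown sits. Compound 4 `COc1ccc2[nH]c(C(=O)N3CC(=O)N(Cc4ccccc4)[C@@H](CN4CCN(c5ccccn5)CC4)C3)cc2c1` is the unmeasured member, differing from compound 1 by 4-(pyridin-2-yl)piperazin-1-yl in place of benzyloxy on a saturated chain carbon bound to a saturated ring carbon. The measured steps all change the substituent on the saturated ring carbon: an at least 21-fold lower number from compound 1 to compound 2 (1.33 log units; beyond the scatter) and an at least 71-fold higher number from compound 2 to compound 3 (1.85 log units; beyond the scatter), while a step that the two limits leave unreadable from compound 1 to compound 3. None of them replaces the benzyloxy on the chain carbon while keeping the chain, so they bear only loosely on compound 4. Given that two of three values sit at limits, compound 4 is expected to remain near the limit of compound 1, with a step of a number no higher from compound 1 to compound 4 (the limit leaves the size open) not beyond the scatter in either direction. The estimate for compound 4 in this assay is 30000 nM, between 8000 nM and 100000 nM.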

Compound 4, half-maximal cytotoxic concentration: > 30000 nM
Compound 4 gave a limit, no number (the forecaster's own chance of this, stated with the estimate: 55%); the middle value sits exactly at the limit.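

Compound 1 and compound 4 both stand at a limit in this assay, not at a number, so the step between them cannot be read. The compounds shown leave open whether 4-(pyridin-2-yl)piperazin-1-yl in place of benzyloxy on this chain changes the read-out at all.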